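The source may hold more compounds than are shown below. What is called first, only, known or untested is meant among the compounds shown, and "the series" means these compounds.

Among the measured compounds shown here, compound 1 `COc1nc(C)c(Nc2nc(Cl)cn([C@H](CO)C3CC3)c2=O)cc1C` is the parent of this small set: in an assay on frontal cortex for displacement of a labelled ligand from corticotropin-releasing factor receptor 1 (Rattus norvegicus), with a stated time of 2 h (a higher number here means a weaker inhibitor, a lower number a stronger inhibitor), compound 1 gives 88 nM, the highest of the three numbers measured so far. Its two esterified relatives sit well away from it. Compound 2 `COc1nc(C)c(Nc2nc(Cl)cn([C@H](COC(=O)c3ccccc3)C3CC3)c2=O)cc1C` gives 1.5 nM, and the step of a 59-fold lower number from compound 1 to compound 2 (1.77 log units; beyond the scatter) is the largest in the set. Compound 3 `COc1nc(C)c(Nc2nc(Cl)cn([C@H](COC(=O)Nc3ccc(Cl)cc3)C3CC3)c2=O)cc1C` gives 1.6 nM; the step of a 55-fold lower number from compound 1 to compound 3 (1.74 log units; beyond the scatter) is almost the same size. Between the two acylated compounds nothing separates them, since a 1.1-fold higher number from compound 2 to compound 3 (0.03 log units; within the scatter).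

Compound 4 `COc1nc(C)c(Nc2nc(Cl)cn([C@H](COC(=O)Nc3cccc(C#N)c3)C3CC3)c2=O)cc1C` is the next carbamate. Relative to compound 1 the change is (3-cyanophenyl)carbamoyl in place of hydrogen on an oxygen on a saturated carbon. The steps from compound 1 to compound 2 and from compound 1 to compound 3 both bear on it directly: each time the hydrogen on that oxygen was replaced by an acyl group the number fell by a large margin, and the phenyl against (4-chlorophenyl)amino swap made no difference beyond the scatter. A comparably large drop is therefore expected for compound 4, estimated as a 44-fold lower number from compound 1 to compound 4 (1.64 log units; beyond the scatter). The expected value for compound 4 is 2 nM, with a range from 0.7 nM to 8 nM.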

Compound 4, half-maximal inhibitory concentration: 1.3 nM
Beside the measured number, compound 4's estimate is 1.5-fold (0.19 log units) above it; measured number inside the range.
By their numbers in this assay, from the lowest: compounds 4, 2 and 3 (each within the scatter of the next); then compound 1.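

In this assay the large step on acylating the oxygen holds for a third aryl group, with a nitrile in place of the chlorine (a 68-fold lower number from compound 1 to compound 4 (1.83 log units; beyond the scatter)). The 3-cyanophenyl and 4-chlorophenyl carbamates are not separated (a 1.2-fold lower number from compound 3 to compound 4 (0.09 log units; within the scatter)), nor are the 3-cyanophenyl carbamate and the benzoate (a 1.2-fold lower number from compound 2 to compound 4 (0.06 log units; within the scatter)), so compound 2, compound 3 and compound 4 form one group at this position, all far from compound 1. No measurement shown accounts for that gap or for the lack of separation among the acylated compounds.

An acetyl ester or a benzyl ether on the same oxygen would test whether the aryl ring or the carbonyl goes with the large step. A carbamate bearing a saturated amine, such as a morpholine, would test whether the aryl group is needed at all.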